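Swapping an Aryl Amide for a Methylisoxazole Amide

The source may hold more compounds than are shown below. What is called first, only, known or untested is meant among the compounds shown, and "the series" means these compounds.

Compound 1: `CCCC(=O)Nc1cccc(NC(=O)COc2ccc3c(=O)ccoc3c2)c1`, 176 nM
Compound 2: `O=C(COc1ccc2c(=O)ccoc2c1)Nc1cccc(NC(=O)c2ccccc2)c1`, 16 nM
Compound 3: `O=C(COc1ccc2c(=O)ccoc2c1)Nc1cccc(NC(=O)c2ccc([N+](=O)[O-])cc2)c1`, 15 nM

All three were measured in an assay on isolated protein for inhibition of Rho-associated protein kinase 2 (Homo sapiens), read by scintillation counting, radiometric assay and 33P incorporation, with a stated time of 40 min, in the presence of a further agent that is not named here; on this read-out higher numbers stand for weaker inhibition and lower numbers for stronger inhibition. Compound 3 gives the lowest number of the set; compound 2 sits within the scatter of it (a 1.1-fold lower number from compound 2 to compound 3 (0.03 log units; within the scatter)), while compound 1 lies well apart (a 12-fold lower number from compound 1 to compound 3 (1.07 log units; beyond the scatter)). Compound 4 (`Cc1cc(C(=O)Nc2cccc(NC(=O)COc3ccc4c(=O)ccoc4c3)c2)no1`) differs from compound 3 by 5-methyl-1,2-oxazol-3-yl in place of 4-nitrophenyl on a carbonyl carbon. The bearing steps are a 12-fold lower number from compound 1 to compound 3 (1.07 log units; beyond the scatter) and an 11-fold lower number from compound 1 to compound 2 (1.04 log units; beyond the scatter), both large, showing that an aromatic group on that carbonyl carbon is what carries the gain, whereas a 1.1-fold lower number from compound 2 to compound 3 (0.03 log units; within the scatter) shows the nitro itself adding nothing beyond the scatter. Since a smaller heteroaromatic ring replaces the aryl, compound 4 is expected to keep most of the activity, with a 2.0-fold higher number from compound 3 to compound 4 (0.30 log units; within the scatter). The estimate for compound 4 in this assay is 30 nM, expected to lie between 8 nM and 120 nM.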

Compound 4, half-maximal inhibitory concentration: 5 nM
Compound 4: middle estimate off by 6.0-fold (0.78 log units), on the high side; the whole stated range lies above it.
By their numbers in this assay, from the lowest: compound 4; then compounds 3 and 2 (each within the scatter of the next); then compound 1.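

At this carbonyl carbon a six-membered aromatic ring of carbon only is not needed: 5-methyl-1,2-oxazol-3-yl, with fewer heavy atoms, goes beyond both aryl groups, giving a 3.0-fold lower number from compound 3 to compound 4 (0.48 log units; beyond the scatter) and a 3.2-fold lower number from compound 2 to compound 4 (0.51 log units; beyond the scatter). Measured against propyl, the change gives a 35-fold lower number from compound 1 to compound 4 (1.55 log units; beyond the scatter), so the gain at this place does not stop at the phenyl and 4-nitrophenyl level. Nothing available explains why this ring gives the lower number. Still open, going by these compounds, is whether the methyl on the ring contributes, and how a pyridine or thiophene ring would behave on the same carbonyl carbon.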